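3,4,5-trifluorobenzyl to methyl on compound 1

The compounds below may be only part of what the source reports. "The series", "measured", "known", "first", "only" and "open" are said of these compounds alone.

Measured in a functional assay on HCT-116 cells (Homo sapiens) for cytotoxicity, read by sulforhodamine B assay; on this read-out lower numbers stand for stronger inhibition of growth and higher numbers for weaker inhibition of growth:
- compound 1 `Nc1ncnc2c1nc(NCc1ccc(Cl)c(Cl)c1)n2[C@@H]1O[C@H](COCc2cc(F)c(F)c(F)c2)[C@@H](O)[C@H]1O` gives 13000 nM
- compound 2 `N#Cc1ccc(COC[C@H]2O[C@@H](n3c(NCc4ccccc4)nc4c(N)ncnc43)[C@H](O)[C@@H]2O)cc1` gives > 80000 nM, a limit
- compound 3 `Nc1ncnc2c1nc(NCc1ccc3ncccc3c1)n2[C@@H]1O[C@H](COCc2cc(F)c(F)c(F)c2)[C@@H](O)[C@H]1O` gives 18000 nM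

Within the data shown here, compound 1 stands within the scatter of compound 3, the only other compound with a number. The result for compound 2 is a limit. The step to compound 4 `COC[C@H]1O[C@@H](n2c(NCc3ccc(Cl)c(Cl)c3)nc3c(N)ncnc32)[C@H](O)[C@@H]1O` is hydrogen in place of 3,4,5-trifluorophenyl on a saturated chain carbon bound to an oxygen on a saturated carbon, the same difference read as 3,4,5-trifluorobenzyl to methyl. Among the measured compounds shown here, the only measured step, a 1.4-fold higher number from compound 1 to compound 3 (0.14 log units; within the scatter), changes another place and gives no size for this change. With a whole aromatic ring leaving, a step beyond the scatter towards weaker inhibition of growth in this assay is expected, starting from compound 1 at 13000 nM and resting on little data. The expected size is an estimated 3.1-fold higher number from compound 1 to compound 4 (0.49 log units; beyond the scatter) here. Compound 4 is expected at about 40000 nM, with an estimated range from 16000 nM to 80000 nM for now.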

Compound 4, concentration for 50% growth inhibition: > 80000 nM
Compound 4 was reported as a limit (the forecaster's own chance of this, stated with the estimate: 40%); middle value at least 2.0-fold (0.30 log units) away from the limit.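

In this assay, going from 3,4,5-trifluorobenzyl to methyl gives an at least 6.1-fold higher number from compound 1 to compound 4 (0.78 log units; beyond the scatter), the first step in the series shown that lies beyond the scatter. The value of compound 4 is a limit, so this step gives a minimum and not a full size: the limit of > 80000 nM in this assay, at which 2 of the 4 values shown sit. Growth inhibition in this assay therefore responds to the group at this place, which the earlier step, at another place, could not show.

Whether the aromatic ring or the fluorines account for this remains open. An unsubstituted benzyl, a hexyl chain or an aminoethyl group at this place would help separate these possibilities.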